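A few compounds are considered here, and "the series" means these few. Any claim that something is new, unique, unknown or untested is made for them only; others in the source may bear on it.

Measured so far:
compound 1 `O=C(/C(=C\c1csc([N+](=O)[O-])c1)S(=O)(=O)c1ccc(Br)cc1)c1ccc(Br)cc1`: 1000 nM
compound 2 `COc1ccc(/C=C(\C(=O)c2ccc(Br)cc2)S(=O)(=O)c2ccc(Br)cc2)c(F)c1`: 10000 nM

In a functional assay on DU-145 cells (Homo sapiens) for inhibition, read by trypan blue exclusion, with a stated time of 96 h (a higher number here means a weaker inhibitor of growth, a lower number a stronger inhibitor of growth), compound 2 gives 10000 nM, the higher of the two numbers and so the weaker inhibitor of growth of this pair. For the measured compounds named here, the only measured step is a 10-fold higher number from compound 1 to compound 2 (1.00 log units; beyond the scatter), and it comes from 2-fluoro-4-methoxyphenyl replacing 5-nitrothiophen-3-yl on a double-bonded chain carbon bound to a double-bonded chain carbon.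

Compound 3 `O=C(/C(=C\c1ccc(Cl)cc1Cl)S(=O)(=O)c1ccc(Br)cc1)c1ccc(Br)cc1` is not yet measured. It changes that same place again: 2,4-dichlorophenyl in place of 2-fluoro-4-methoxyphenyl on a double-bonded chain carbon bound to a double-bonded chain carbon, with 2,4-dichlorophenyl in place of 2-fluoro-4-methoxyphenyl. Going by the values given here, the step to compound 2 is the one piece of evidence here, and it shows that a swap at this place can move the number beyond the scatter. Among the compounds with values here, it does not set the direction for this swap, since no other compound with a 2,4-dichlorophenyl group has been measured. Within the data shown here, compound 2 also stands at the high end of the numbers so far, so a modest step toward a lower number is expected in this assay, though a result within the scatter remains possible.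

The estimated step is a 2.5-fold lower number from compound 2 to compound 3 (0.40 log units; beyond the scatter). The estimated value for compound 3 is 4000 nM, with an expected range from 1000 nM to 15000 nM.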

Compound 3, concentration for 50% growth inhibition: 10000 nM
Compound 3: middle estimate off by 2.5-fold (0.40 log units), on the low side; the range from low to high includes it.
By their numbers in this assay, from the lowest: compound 1; then compounds 2 and 3 (each within the scatter of the next).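

In this assay the swap at this place gives no change at the digits printed from compound 2 to compound 3 (within the scatter) and so shows that this position does not respond to every change of group: the 2-fluoro-4-methoxyphenyl and 2,4-dichlorophenyl compounds cannot be told apart here, although their substituents differ. The second comparison gives a 10-fold higher number from compound 1 to compound 3 (1.00 log units; beyond the scatter) and matches the size of the earlier step, so compound 1, with its 5-nitrothiophen-3-yl group, now stands apart from two different substituted phenyl compounds rather than from one. No measurement of any property of these compounds bears on this result.

Going by these compounds, whether the lower number of compound 1 goes with the nitro group or with the thiophene ring stays open, since the two enter together in these compounds. A nitrophenyl group or an unsubstituted thiophene at this place on the double-bonded chain carbon would separate the two, and an aminophenyl group would show whether the nitro group can be replaced by a nitrogen group of another kind.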